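From Benzyl to Benzoyl on the Ring Nitrogen

The compounds below may be only part of what the source reports. "The series", "measured", "known", "first", "only" and "open" are said of these compounds alone.

Three compounds sharing one core have been examined in a physicochemical assay for solubility, with a stated time of 3 days, at pH 7; on this read-out higher numbers stand for higher solubility and lower numbers for lower solubility. For compound 1 `CN1CCC(Oc2ccc(-c3nc4cc(C(N)=O)ccc4[nH]3)cc2)C1` the result stands as "not determined" (no result reported). Compound 2 `NC(=O)c1ccc2[nH]c(-c3ccc(OCC4CCNCC4)cc3)nc2c1` returned only a limit of the assay, > 400000 nM. Among the compounds with values here, compound 3 `NC(=O)c1ccc2[nH]c(-c3ccc(OCCC4CCN(Cc5ccccc5)CC4)cc3)nc2c1`, at 5000 nM, therefore carries the only actual number in the set, and it is the natural point of comparison for what follows.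

Compound 4 `NC(=O)c1ccc2[nH]c(-c3ccc(OCCC4CCN(C(=O)c5ccccc5)CC4)cc3)nc2c1` has benzoyl in place of the benzyl of compound 3, on an amine nitrogen in a ring: benzoyl in place of benzyl on an amine nitrogen in a ring. Within the data shown here, no measured pair isolates this exchange, so the expectation rests on the single number for compound 3 and remains loose. A moderate downward move in this assay is expected, slightly beyond the usual scatter, and the expected change is a 2.5-fold lower number from compound 3 to compound 4 (0.40 log units; beyond the scatter). For compound 4 the estimated value is 2000 nM, with an expected range from 300 nM to 12000 nM.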

Compound 4, solubility: 3000 nM
Compound 4: middle estimate off by 1.5-fold (0.18 log units), on the low side; low and high end bracket the measured number.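

In this assay, within the data shown here, the first step that can be read at this position is a 1.7-fold lower number from compound 3 to compound 4 (0.22 log units; within the scatter), for benzoyl in place of benzyl on an amine nitrogen in a ring. The entering group adds one oxygen, a double bond outside the aromatic ring and a hydrogen-bond acceptor, yet compound 3 and compound 4 cannot be told apart on this read-out, so at this position the exchange leaves no mark beyond the usual scatter. Nothing shown here gives a cause for this result.

The compounds shown leave open how an acetyl or a methanesulfonyl group on this ring nitrogen would read, and whether a carboxylic acid on the benzoyl ring would carry the number beyond the scatter. Compound 2, with its ring nitrogen unsubstituted and a shorter chain, gives only a limit of the assay, > 400000 nM.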